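The source may report more compounds than this note shows. Statements on the series, on what has been measured and on what is new or still open speak of the compounds shown alone.

In an ADME assay on CHO cells (Cricetulus griseus) for cytotoxicity, read by LDH release (a higher number here means a weaker inhibitor, a lower number a stronger inhibitor), three close relatives set the scene. Compound 1 (`CC(Oc1ccc(Cl)cc1Cl)C(=O)NCc1ccccc1Cl`) gives > 100000 nM, which is a limit of the assay and not a number. Compound 2 (`COc1ccc(CNC(=O)C(C)Oc2ccc(Cl)cc2Cl)cc1`) gives 71000 nM. Compound 3 (`COc1ccccc1CNC(=O)C(C)Oc1ccc(Cl)cc1Cl`) has no number to stand on, since its entry reads "not determined" (no result reported). Compound 4 (`COc1ccc(CNC(=O)C(C)Oc2ccc(Cl)cc2Cl)c(OC)c1`) comes from compound 3 through one change, (methoxy in place of hydrogen on an aromatic carbon), with methoxy in place of hydrogen on an aromatic carbon. Within the data shown here, no measured pair shows what such a change does. Among the measured compounds shown here, with compound 2 at 71000 nM as the only exact value, no step beyond the scatter is expected in this assay. Compound 4 is expected at about 70000 nM, within an estimated range from 30000 nM to 100000 nM.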

Compound 4, half-maximal inhibitory concentration: > 100000 nM
Compound 4: no number, only a limit; the forecaster's own chance of this, stated with the estimate: 40%; middle value at least 1.4-fold (0.15 log units) from the limit.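

In this assay, a methoxy group in place of hydrogen on an aromatic carbon gives an at least 1.4-fold higher number from compound 2 to compound 4 (0.14 log units; that floor lies within the scatter), so this second methoxy brings no sign of a stronger inhibitor. The result for compound 4 is a limit and not a number: the limit of > 100000 nM in this assay, at which 2 of the 4 values shown sit. With no result for compound 3, the step to compound 4 from that side cannot be read.

On these data alone, how far compound 4 lies beyond its limit remains open. So does whether an amine or a carboxylic acid at this position would give a lower number in this assay.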